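Series notes: carbamoyl in place of sulfonyl

A few compounds are considered here, and "the series" means these few. Any claim that something is new, unique, unknown or untested is made for them only; others in the source may bear on it.

In a functional assay on MDA-MB-436 cells (Homo sapiens) for antiproliferative activity, read by MTT assay, with a stated time of 48 h (a lower number here means a stronger inhibitor, a higher number a weaker inhibitor), compound 1 (`C=CS(=O)(=O)N1CCN(c2ncnc3sc(-c4cc(Br)cnc4F)cc23)CC1`) gives 28400 nM as its value. Compound 2 (`CN1CCN(c2ccc(-c3cc4c(N5CCN(S(=O)(=O)N6CCCCC6)CC5)ncnc4s3)cc2)CC1`) gives 7570 nM as the lower of the two numbers, and its gap to compound 1 lies beyond the scatter. These two compounds differ in more than one place, so their gap cannot be tied to any single group.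

Compound 3 (`COc1ccc(NC(=O)N2CCN(c3ncnc4sc(-c5ccc(N6CCN(C)CC6)cc5)cc34)CC2)cc1`) departs from compound 2 by a single exchange: (4-methoxyphenyl)carbamoyl in place of (piperidin-1-yl)sulfonyl on an amine nitrogen in a ring. Going by the values given here, the data hold no measured step for an exchange at this place, so the size of the step cannot be read from precedent. The closest reference is compound 2 at 7570 nM for this estimate. Expected in this assay is a 1.5-fold lower number from compound 2 to compound 3 (0.18 log units; within the scatter) as an estimated step, which means no change beyond the scatter, with only a slight lean towards a lower number. For compound 3 the estimated value is 5000 nM with an expected range from 1500 nM to 18000 nM in this read-out.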

Compound 3, half-maximal inhibitory concentration: 30100 nM
Beside the measured number, compound 3's estimate is 6.0-fold (0.78 log units) below it, and the stated range ends below it.
By their numbers in this assay, from the lowest: compound 2; then compounds 1 and 3 (each within the scatter of the next).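

In this assay, going by these compounds alone, the exchange of (piperidin-1-yl)sulfonyl for (4-methoxyphenyl)carbamoyl gives a 4.0-fold higher number from compound 2 to compound 3 (0.60 log units; beyond the scatter), the only step so far that can be tied to one place. It shows that the group on this amine nitrogen in a ring affects the read-out, since the step lies beyond the scatter and runs towards the weaker inhibitor. The exchange replaces the sulfonyl with a carbonyl, a six-membered non-aromatic ring with a six-membered aromatic ring of carbon only, and adds a hydrogen-bond donor, while no measurement here accounts for the step.

The compounds shown leave open which of these features carries the step, and a (piperidin-1-yl)carbonyl or a (4-methoxyphenyl)sulfonyl group at the same nitrogen would separate the linking group from the ring it carries. Also open, from the compounds shown here alone, is what the methoxy group contributes, which a plain phenylcarbamoyl or a 4-chlorophenylcarbamoyl group on the same nitrogen would address.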